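This account rests on a few compounds, and the source may have more. Where it says the series, first, only, none or still open, it means among the compounds named here.

Measured compounds in an assay on CHO cells for displacement of a labelled ligand from D(4) dopamine receptor (Homo sapiens), read by radioligand binding; on this read-out lower numbers stand for stronger inhibition and higher numbers for weaker inhibition:

compound 1, `COc1ccccc1N1CCN(CCCNC(=O)NN(Cc2ccccc2)c2ccc(Cl)cc2)CC1`, gives 2.9 nM
compound 2, `COc1ccccc1N1CCN(CCCNC(=O)NN(Cc2ccccc2)c2ccc(Br)cc2)CC1`, gives 3.4 nM
compound 3, `O=C(NCCCN1CCN(c2ccc(Cl)cc2)CC1)NN(Cc1ccccc1)c1ccccc1`, gives 9.7 nM

Compound 1 and compound 2 share one core and differ in a single place, (bromo in place of chloro on an aromatic carbon). The step this change made in this assay was a 1.2-fold higher number from compound 1 to compound 2 (0.07 log units; within the scatter). Compound 3 carries a different core; how its core differs from that of compound 1 is not broken down here, and what can be said is that compound 3 gives the highest of the three numbers, with both other compounds sitting beyond the scatter below it.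

Compound 4, `O=C(NCCCN1CCN(c2ccc(Br)cc2)CC1)NN(Cc1ccccc1)c1ccccc1`, has not yet been measured. It stands to compound 3 as compound 2 stands to compound 1: the difference is bromo in place of chloro on an aromatic carbon, and the surroundings of the place are the same word for word, so this is the same change. Because the earlier instance gave a 1.2-fold higher number from compound 1 to compound 2 (0.07 log units; within the scatter), the expected step is a 1.1-fold higher number from compound 3 to compound 4 (0.05 log units; within the scatter), also within the scatter. Compound 4 is therefore estimated at 11 nM, with a range from 5 nM to 25 nM.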

Compound 4, inhibition constant: 14 nM
For compound 4 the middle estimate is 1.3-fold (0.10 log units) below the measured one, within the range that was stated.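

In this assay, bromo in place of chloro on the second core gave a 1.4-fold higher number from compound 3 to compound 4 (0.16 log units; within the scatter), so the change again stayed within the scatter. Set side by side, the two instances do not differ: the same change on two cores in this assay, a 1.2-fold higher number (0.07 log units; within the scatter) from compound 1 to compound 2 and a 1.4-fold higher number (0.16 log units; within the scatter) from compound 3 to compound 4, 1.2-fold (0.09 log units) apart, within the scatter of two such steps

This shows that, on these two cores, the exchange of these two halogens carried over with no step beyond the scatter, and that a value for a chloro compound served as a fair guide to its bromo partner. It does not show that the same would hold on any other core, and two steps of this size within the scatter cannot establish that bromo and chloro truly differ in this assay.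

The compounds shown leave open what other groups would do at the same place, such as fluoro, methyl, methoxy or a plain hydrogen, as only chloro and bromo appear in these pairs. They also leave open whether the step would hold on a core with a longer chain.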